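From Cyano to Aminomethyl on the Amide Side Chain

The source may hold more compounds than are shown below. What is called first, only, known or untested is meant among the compounds shown, and "the series" means these compounds.

Measured so far in a functional assay on PC-3 cells (Homo sapiens) for antiproliferative activity, read by MTT assay, with a stated time of 48 h; on this read-out lower numbers stand for stronger inhibition and higher numbers for weaker inhibition:
compound 1 `CCn1c(C(=O)NCCCN(C)C)ccc1C(CC)(CC)c1ccc(OCCC(O)(CC)CC)c(C)c1`: 2150 nM
compound 2 `CCn1c(C(=O)NCC#N)ccc1C(CC)(CC)c1ccc(OCCC(O)(CC)CC)c(C)c1`: 17800 nM

Compound 2 gives 17800 nM, the higher of the two numbers, so it is the weaker of the pair, and the gap to compound 1 lies beyond the scatter. The unmeasured compound 3 `CCn1c(C(=O)NCCN)ccc1C(CC)(CC)c1ccc(OCCC(O)(CC)CC)c(C)c1` keeps the shared core and differs from compound 2 in one group: aminomethyl in place of cyano on a saturated chain carbon bound to an amide-type nitrogen. In words, this is aminomethyl in place of cyano on a saturated chain carbon bound to an amide-type nitrogen.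

Among the measured compounds shown here, only one measured step bears on this change: an 8.3-fold higher number from compound 1 to compound 2 (0.92 log units; beyond the scatter). That modest step put cyano in place of 2-(dimethylamino)ethyl at the same place. Compound 3 also lacks the cyano, but its aminomethyl is not the group carried by compound 1, so only part of that step is expected to return. The step expected in this assay is a 3.6-fold lower number from compound 2 to compound 3 (0.55 log units; beyond the scatter), towards a lower number. For compound 3 the estimate is 5000 nM, with an expected range from 1800 nM to 14000 nM.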

Compound 3, half-maximal inhibitory concentration: 2420 nM
For compound 3 the middle estimate is 2.1-fold (0.32 log units) above the measured one; the measured number falls inside the stated range.
By their numbers in this assay, from the lowest: compounds 1 and 3 (each within the scatter of the next); then compound 2.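

In this assay, the earlier pair showed only that cyano on a saturated chain carbon bound to an amide-type nitrogen went with a weaker result than the 2-(dimethylamino)ethyl of compound 1. The new result shows that this gap does not depend on that exact group: aminomethyl in place of cyano gives a 7.4-fold lower number from compound 2 to compound 3 (0.87 log units; beyond the scatter) and so closes it, while amino in place of (dimethylamino)methyl on a saturated chain carbon, two bonds along the chain from an amide-type nitrogen, gives a 1.1-fold higher number from compound 1 to compound 3 (0.05 log units; within the scatter) and leaves compound 1 and compound 3 within the scatter of each other. No measurement at hand accounts for either step.

The compounds shown leave open whether a carboxylic acid or a hydroxyl at the end of this chain would stay with compound 3 or fall back towards compound 2. They also leave open whether a longer chain ending in a primary amine, or a piperidine in the same place, would hold the level seen with compound 1 and compound 3.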